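The compounds below may be only part of what the source reports. "The series", "measured", "known", "first", "only" and "open" are said of these compounds alone.

Measured compounds:
- Compound 1 `CCN(CC)C(=O)CN(c1cc(Cl)ccc1OC)S(=O)(=O)c1ccccc1`: in a functional assay on SH-SY5Y cells (Homo sapiens), read by MTT assay, with a stated time of 24 h (a higher number here means that more compound is needed for the effect, a lower number that less compound is needed), compound 1 gives > 20000 nM, which is a limit of the assay and not a number.
- Compound 2 `COc1ccc(CNC(=O)CN(c2cc(Cl)ccc2OC)S(=O)(=O)c2ccccc2)cc1`: in this assay compound 2 gives > 20000 nM, again a limit of the assay.
- Compound 3 `COc1cccc(NC(=O)CN(c2cc(Cl)ccc2OC)S(=O)(=O)c2ccccc2)c1`: in this assay compound 3 gives 17600 nM.

Among the measured compounds shown here, compound 3 therefore stands as the only real number among the three values shown; the other two sit at the limit of > 20000 nM in this assay, at which 2 of the 3 values shown sit. For the measured compounds named here, the two steps leading to it, an at least 1.1-fold lower number from compound 1 to compound 3 (0.05 log units; that floor lies within the scatter) and an at least 1.1-fold lower number from compound 2 to compound 3 (0.05 log units; that floor lies within the scatter), have floors that lie within the scatter, so they say only that compound 3 is readable while the others are not.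

Compound 4 `COc1ccc(Cl)cc1N(CC(=O)Nc1ccc([N+](=O)[O-])cc1)S(=O)(=O)c1ccccc1` differs from compound 3 in one place: 4-nitrophenyl in place of 3-methoxyphenyl on an amide-type nitrogen. Going by the values given here, none of the measured steps exchanges one ring substituent for another on this amide-type nitrogen; the measured steps replace the whole group on that nitrogen and end in limits, so they offer no direction for this change. The expected step is therefore none beyond the scatter, a 1.0-fold higher number from compound 3 to compound 4 (0.01 log units; within the scatter). Compound 4 is estimated at 18000 nM in this assay, with a range from 7000 nM to 45000 nM.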

Compound 4, half-maximal effective concentration: 8210 nM
Beside the measured number, compound 4's estimate is 2.2-fold (0.34 log units) above it, within the range that was stated.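

Exchanging one ring substituent on this amide-type nitrogen does move the number in this assay: 4-nitrophenyl in place of 3-methoxyphenyl gives a 2.1-fold lower number from compound 3 to compound 4 (0.33 log units; beyond the scatter). This is the first step among the compounds shown that has a real number at both ends and lies beyond the scatter, so the ring on this nitrogen is a place where the read-out responds to a change. Two further steps, an at least 2.4-fold lower number from compound 2 to compound 4 (0.38 log units; beyond the scatter) and an at least 2.4-fold lower number from compound 1 to compound 4 (0.38 log units; beyond the scatter), also lie beyond the scatter, though each starts from a limit of the assay and gives only a floor: the limit of > 20000 nM in this assay, at which 2 of the 4 values shown sit.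

From the compounds shown here alone, whether the lower number belongs to the nitro group or to its place on the ring stays open, and 3-nitrophenyl or 4-methoxyphenyl on the same nitrogen would separate the two. Going by these compounds, how other groups at that place compare, such as a nitrile or an amine, also stays open.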